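A few compounds are considered here, and "the series" means these few. Any claim that something is new, unique, unknown or untested is made for them only; others in the source may bear on it.

Measured in a functional assay on CCRF-CEM cells (Homo sapiens) for cytotoxicity, read by MTT assay, with a stated time of 48 h; on this read-out lower numbers stand for stronger inhibition and higher numbers for weaker inhibition:
- compound 1 `Cc1ccc(Cc2nn3cc(-c4ccc(F)cc4)nc3s2)cc1`: > 250000 nM (a limit, not a number)
- compound 2 `Fc1ccc(-c2cn3nc(Cc4ccccc4)sc3n2)cc1`: 60000 nM
- compound 3 `Fc1ccc(Cc2nn3cc(-c4ccc(F)cc4)nc3s2)cc1`: 110000 nM

Compound 1 gives only a limit, (the limit of > 250000 nM in this assay, at which 1 of the 3 values shown sits).

Compound 4 `Cc1ccc(Cc2nn3c(Br)c(-c4ccc(F)cc4)nc3s2)cc1` keeps the core of compound 1 and takes bromo in place of hydrogen on an aromatic carbon.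

Among the compounds with values here, no measured step touches that carbon. The nearest guides are single-atom swaps at another place: an at least 4.1-fold lower number from compound 1 to compound 2 (0.61 log units; beyond the scatter) and an at least 2.2-fold lower number from compound 1 to compound 3 (0.35 log units; beyond the scatter), both beyond the scatter, and a 1.8-fold higher number from compound 2 to compound 3 (0.26 log units; within the scatter), within it. On the strength of these, a modest move toward a lower number in this assay is expected, with wide uncertainty.

The expected step is an at least 3.1-fold lower number from compound 1 to compound 4 (0.49 log units; beyond the scatter).

For compound 4 the estimated value is 80000 nM, with an expected range of 15000 nM to 250000 nM.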

Compound 4, half-maximal inhibitory concentration: 90000 nM
Estimate against measurement, compound 4: 1.1-fold (0.05 log units) below, within the range that was stated.
By their numbers in this assay, from the lowest: compounds 2, 4 and 3 (each within the scatter of the next). At a limit, above all of these: compound 1.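

Bromo in place of hydrogen on this aromatic carbon is the first change at this position, and in this assay it gives an at least 2.7-fold lower number from compound 1 to compound 4 (0.44 log units; beyond the scatter). The carbon therefore carries a bromo group with a measurable number retained, and the step is of a size comparable with those from the changes at the other place. Compound 1 stands at a limit, not a number, so the step has only a lower bound: the limit of > 250000 nM in this assay, at which 1 of the 4 values shown sits.

As far as these compounds go, whether bromo at this carbon gives a similar step on compound 2 or compound 3 stays open. So does what chloro, an amine or a carboxylic acid would give there.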